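Shortening the Amide Chain of a Cinnamamide

The source may report more compounds than this note shows. Statements on the series, on what has been measured and on what is new or still open speak of the compounds shown alone.

Measured so far:
compound 1 `CCCCCCNC(=O)/C=C/c1ccccc1`: 82%
compound 2 `CCCCCCCCCCNC(=O)/C=C/c1ccccc1`: 15%
compound 3 `Cc1ccc(C(C)C)c(OC(=O)/C=C/c2ccc(C(C)C)cc2)c1`: 30%

Of the compounds shown here, three have been tested in a functional assay on the whole organism for inhibition, with Brassica rapa subsp. chinensis as the target, with a stated time of 3 days, tested at 100 ppm; on this read-out higher numbers stand for more inhibition of growth at the one concentration tested and lower numbers for less inhibition of growth. Compound 1 gives 82%, the highest of the three numbers. Its nearest neighbour is compound 3 with 30%, and furthest away is compound 2 with 15%, both differences beyond the scatter.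

Compound 4 `CC(C)CNC(=O)/C=C/c1ccccc1` is not yet measured. It differs from compound 1 in one place: isopropyl in place of pentyl on a saturated chain carbon bound to an amide-type nitrogen. The chain attached to the amide-type nitrogen thus becomes shorter and branched.

Going by the values given here, the only measured step that bears on this is a number 67 percentage points lower from compound 1 to compound 2 (beyond the scatter), where the chain was made longer. The change toward compound 4 goes the other way, and nothing measured shows what a shorter chain does. Given that the one known step moved the read-out far, a step of some size from compound 1 to compound 4 is possible in either direction, but the expectation is a small one, a number 12 percentage points lower from compound 1 to compound 4 (beyond the scatter). Compound 4 is therefore estimated at 70%, with a range from 40% to 95%.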

Compound 4, percent growth inhibition at one concentration: 78%
Beside the measured number, compound 4's estimate is 8 percentage points below it; the range from low to high includes it.
By their numbers in this assay, from the lowest: compound 2; then compound 3; then compounds 4 and 1 (each within the scatter of the next).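

In this assay, replacing pentyl with isopropyl on a saturated chain carbon bound to an amide-type nitrogen gives a number 4 percentage points lower from compound 1 to compound 4 (within the scatter), so this shorter, branched group keeps the read-out of the longer pentyl. Until now, the only change seen at this chain was a lengthening, with a number 67 percentage points lower from compound 1 to compound 2 (beyond the scatter), and the new step shows that the two directions of change in chain size do not behave alike among these compounds. No measured evidence is at hand to explain this result.

Isopropyl makes the chain both shorter and branched, so these compounds cannot separate the two changes, and a straight propyl chain in the same place would be needed to do so. Also open, as far as these compounds go, is how this place would respond to a methyl group, an amine or a carboxylic acid.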